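Pyridin-4-yl in Place of Phenyl on Two Cores

A few compounds are considered here, and "the series" means these few. Any claim that something is new, unique, unknown or untested is made for them only; others in the source may bear on it.

In an assay on isolated protein for displacement of a labelled ligand from 5-hydroxytryptamine receptor 6 (Homo sapiens), read by scintillation counting, with a stated time of 1 h (a lower number here means a stronger inhibitor, a higher number a weaker inhibitor), three compounds have been measured so far:

Compound 1, `O=S(=O)(c1ccccc1)n1cc(-c2ccccc2)c2ccccc21`, gives 146 nM.
Compound 2, `O=S(=O)(c1ccccc1)n1cc(-c2ccncc2)c2ccccc21`, gives 124 nM.
Compound 3, `O=S(=O)(c1ccccc1)n1ccc2cc(-c3ccccc3)ccc21`, gives 558 nM.

Compound 1 and compound 2 share a core and differ in one place: pyridin-4-yl in place of phenyl on an aromatic carbon. That change made a step of a 1.2-fold lower number from compound 1 to compound 2 (0.07 log units; within the scatter), so the two values are not distinguishable here. Compound 3 is built from the same atoms as compound 1, joined differently; the difference between the two cores is not broken down here. Compound 3 stands highest of the three numbers, and its gap to compound 1 and to compound 2 lies beyond the scatter.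

Compound 4, `O=S(=O)(c1ccccc1)n1ccc2cc(-c3ccncc3)ccc21`, has not been measured. It relates to compound 3 as compound 2 relates to compound 1: pyridin-4-yl in place of phenyl on an aromatic carbon. The place differs, however: in compound 1 the group sits on a five-membered aromatic ring with 1 nitrogen, whereas in compound 3 it sits on a six-membered aromatic ring of carbon only, meta to a fused ring and para to a fused ring. It is therefore the same kind of change, not the same change.

Because the earlier step of a 1.2-fold lower number from compound 1 to compound 2 (0.07 log units; within the scatter) stayed within the scatter, compound 4 is expected to lie close to compound 3, with an estimated step of a 1.2-fold lower number from compound 3 to compound 4 (0.07 log units; within the scatter). The estimate for compound 4 in this assay is 470 nM, expected between 200 nM and 1100 nM.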

Compound 4, inhibition constant: 409 nM
Beside the measured number, compound 4's estimate is 1.1-fold (0.06 log units) above it; the range from low to high includes it.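

Pyridin-4-yl in place of phenyl on an aromatic carbon of the second core made a step of a 1.4-fold lower number from compound 3 to compound 4 (0.13 log units; within the scatter) so the two values cannot be told apart in this assay. Set beside the earlier step, the change carried from one core to the other with no difference in size that can be read: the same change on two cores in this assay, a 1.2-fold lower number (0.07 log units; within the scatter) from compound 1 to compound 2 and a 1.4-fold lower number (0.13 log units; within the scatter) from compound 3 to compound 4, 1.2-fold (0.06 log units) apart, within the scatter of two such steps. This shows that, on these two cores and at these two places, the change left the number where it stood, but it does not show that the same would hold on any other core or at any other place, and it does not explain the gap between the two phenyl compounds.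

The compounds shown leave open whether a different group at these places, such as an amine, a carboxylic acid or a longer chain, would move the number beyond the scatter. They also leave open whether pyridin-3-yl would behave as pyridin-4-yl does on either core.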